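This account rests on a few compounds, and the source may have more. Where it says the series, first, only, none or still open, it means among the compounds named here.

Three analogues sharing one core have been measured in a functional assay on isolated protein for inhibition of Glucose-dependent insulinotropic receptor (Rattus norvegicus), read by HTRF and cAMP accumulation; a lower number here means that less compound is needed, a higher number that more compound is needed for the effect. Compound 2 `Cc1nc(S(C)(=O)=O)ccc1Oc1ncnc(OC2CCN(C(=O)SC(C)C)CC2)c1F` gives 41.3 nM, the lowest of the three numbers. Compound 1 `Cc1nc(S(C)(=O)=O)ccc1Oc1ncnc(OC2CCN(C(=O)OC3CCC3)CC2)c1F` gives 167 nM, and compound 3 `Cc1nc(S(C)(=O)=O)ccc1Oc1ncnc(OC2CCN(C(=O)C(C)(F)F)CC2)c1F` gives 239 nM. The replacements at the carbonyl carbon have shifted the numbers noticeably: a 4.0-fold lower number from compound 1 to compound 2 (0.61 log units; beyond the scatter), while a 5.8-fold higher number from compound 2 to compound 3 (0.76 log units; beyond the scatter), and a 1.4-fold higher number from compound 1 to compound 3 (0.16 log units; within the scatter).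

Compound 4 `Cc1nc(S(C)(=O)=O)ccc1Oc1ncnc(OC2CCN(C(=O)c3noc(C(C)C)n3)CC2)c1F` differs from compound 2 in a single place: 5-isopropyl-1,2,4-oxadiazol-3-yl in place of isopropylsulfanyl on a carbonyl carbon. Going by the values given here, both measured steps that touch the group on the carbonyl carbon bear on this change, since each exchanged one such group for another; each exchange away from the isopropylsulfanyl group of compound 2 gave a higher number in this assay, by a modest margin, though no measured pair exchanges it for an aromatic ring. A modest rise is therefore expected for compound 4, with considerable uncertainty in both directions. Compound 4 is estimated at 120 nM, in a range from 30 nM to 500 nM, which means an expected step of a 2.9-fold higher number from compound 2 to compound 4 (0.46 log units; beyond the scatter).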

Compound 4, half-maximal effective concentration: 176 nM
For compound 4 the middle estimate is 1.5-fold (0.17 log units) below the measured one, within the range that was stated.
By their numbers in this assay, from the lowest: compound 2; then compounds 1, 4 and 3 (each within the scatter of the next).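

In this assay, placing an aromatic ring on the carbonyl carbon gives a 4.3-fold higher number from compound 2 to compound 4 (0.63 log units; beyond the scatter), so the 5-isopropyl-1,2,4-oxadiazol-3-yl group does not match isopropylsulfanyl. It also does not separate from the other two replacements, with a 1.1-fold higher number from compound 1 to compound 4 (0.02 log units; within the scatter) and a 1.4-fold lower number from compound 3 to compound 4 (0.13 log units; within the scatter). Among the four groups shown on this carbonyl carbon, only the isopropylsulfanyl of compound 2 stands apart, while the cyclobutyloxy, 1,1-difluoroethyl and 5-isopropyl-1,2,4-oxadiazol-3-yl groups give numbers within the scatter of one another, despite the ring and acceptor counts that distinguish the last of them.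

Nothing available explains why isopropylsulfanyl alone stands apart. From the compounds shown here alone, whether an isopropoxy group, with oxygen in place of the sulfur of compound 2, or an amine on the carbonyl carbon would match compound 2 remains open.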